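The source may report more compounds than this note shows. Statements on the series, on what has been measured and on what is new or still open speak of the compounds shown alone.

Compound 1 is `CCC1(Cc2ccccc2)OS(=O)(=O)C=C1OCCCCc1ccccc1`. In an ADME assay on HEL cells (Homo sapiens) for cytotoxicity, with a stated time of 3 days (a higher number here means that more compound is tolerated, a lower number that less compound is tolerated), compound 1 gives >= 20000 nM, which is a limit of the assay and not a number.
Compound 2 is `CCC1(Cc2ccccc2)OS(=O)(=O)C=C1OCc1ccc(F)cc1`. In this assay compound 2 gives >= 50000 nM, again a limit of the assay.
Compound 3 is `CCC1(Cc2ccccc2)OS(=O)(=O)C=C1OCc1cccc(Cl)c1`. In this assay compound 3 gives >= 20000 nM, also a limit of the assay.

Compound 3 therefore stands only at a limit, and the two further values shown are limits as well, so no order among the three compounds can be read. The evidence comes down to the limit of >= 20000 nM in this assay, at which 2 of the 3 values shown sit, and (the limit of >= 50000 nM in this assay, at which 1 of the 3 values shown sits), which is why none of the measured steps has a readable size.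

Compound 4 is `CCC1(Cc2ccccc2)OS(=O)(=O)C=C1OCC=C(C)C`. The change from compound 3 to compound 4 is 2-methylprop-1-en-1-yl in place of 3-chlorophenyl on a saturated chain carbon bound to an oxygen on an unsaturated carbon. The measured steps that touch the same place are a step that the two limits leave unreadable from compound 1 to compound 2, a step that the two limits leave unreadable from compound 1 to compound 3 and a step that the two limits leave unreadable from compound 2 to compound 3; each of them is left unreadable by the two limits, so no direction and no size can be drawn from them for this assay. Given that every compound at this place has so far sat at a limit, compound 4 is expected to behave alike, with an estimated 20000 nM in a range from 10000 nM to 50000 nM. The step of a number no higher from compound 3 to compound 4 (the limit leaves the size open) is thus expected to lie within the scatter, with a high chance that only a limit is reported.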

Compound 4, minimum cytotoxic concentration: 400000 nM
Beside the measured number, compound 4's estimate is 20-fold (1.30 log units) below it; the whole stated range lies below it.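

Compound 4 gives a number, while compound 1, compound 2 and compound 3 stand only at limits of the assay, so none of the steps from them to compound 4 can be read. The compounds shown leave open where those three truly lie in this assay, and whether the 3-methylbut-2-en-1-yl group of compound 4 changes the tolerated concentration at all.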